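Pyrazole amides at the metabotropic glutamate receptor 5

The source may report more compounds than this note shows. Statements on the series, on what has been measured and on what is new or still open speak of the compounds shown alone.

Compound 1 `O=C(Nc1cc(-c2ccccc2)nn1-c1ccccc1)c1ccccc1`: 4180 nM
Compound 2 `O=C(Nc1cc(-c2ccccc2)nn1-c1ccccc1)c1cccc(C(F)(F)F)c1`: 1650 nM
Compound 3 `O=C(Nc1cc(-c2ccccc2)nn1-c1ccccc1Cl)c1ccccc1`: 500 nM

In an assay on HEK293 cells for displacement of a labelled ligand from metabotropic glutamate receptor 5 (Rattus norvegicus) (on this read-out higher numbers stand for weaker inhibition and lower numbers for stronger inhibition), compound 3 gives the lowest number of the three measured compounds, and its steps to compound 1 and to compound 2 both lie beyond the scatter, so it is the strongest inhibitor shown. It was reached from compound 1 by a single change, chloro in place of hydrogen on an aromatic carbon, which gave an 8.4-fold lower number from compound 1 to compound 3 (0.92 log units; beyond the scatter). The other measured step, a 2.5-fold lower number from compound 1 to compound 2 (0.40 log units; beyond the scatter), concerns a trifluoromethyl on the benzamide side and does not touch the ring that is changed next.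

Compound 4 `O=C(Nc1cc(-c2ccccc2)nn1-c1ccccn1)c1ccccc1` differs from compound 3 by pyridin-2-yl in place of 2-chlorophenyl on an aromatic nitrogen. The ring that carried the chloro is thus exchanged for a ring that carries none, and a ring nitrogen enters in its place. For the measured compounds named here, no measured step shows the effect of such a ring nitrogen. The step of an 8.4-fold lower number from compound 1 to compound 3 (0.92 log units; beyond the scatter) does show that the chloro accounted for the whole gain of compound 3 over compound 1, and compound 4 gives that chloro up. The expectation is therefore a higher number in this assay for compound 4, estimated as a 5.0-fold higher number from compound 3 to compound 4 (0.70 log units; beyond the scatter), back toward compound 1 but with wide uncertainty. Compound 4 is estimated at 2500 nM, with a range from 800 nM to 8000 nM.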

Compound 4, inhibition constant: > 10000 nM
Compound 4 gave a limit, no number; the forecaster's own chance of this, stated with the estimate: 5%; middle value at least 4.0-fold (0.60 log units) from the limit.
By their numbers in this assay, from the lowest: compound 3; then compound 2; then compound 1. At a limit, above all of these: compound 4.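

In this assay compound 4 gave a limit and not a number: the limit of > 10000 nM in this assay, at which 1 of the 4 values shown sits. Measured against the chlorinated ring, the change gives an at least 20-fold higher number from compound 3 to compound 4 (1.30 log units; beyond the scatter). For the compounds shown here, measured against the plain phenyl ring, it gives an at least 2.3-fold higher number from compound 1 to compound 4 (0.37 log units; beyond the scatter), so with no chloro in either compound, pyridin-2-yl on this aromatic nitrogen is still worse than phenyl, something the earlier compounds, which all carry a carbon-only ring here, could not show.

The compounds shown leave open whether a chloro on the pyridin-2-yl ring would win back any of the loss, and whether pyridin-3-yl or pyridin-4-yl behaves the same way. They also leave open whether fluoro, methyl or methoxy on the phenyl ring could match the gain seen with chloro.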